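The compounds below may be only part of what the source reports. "The series", "measured", "known", "first", "only" and "open" are said of these compounds alone.

Compound 3 `CC(C)N(Cc1cccc(OCCCCCC(=O)O)c1)C(=O)c1ccc(-c2cccc(O)c2)cc1` was tested in an ADME assay on HEK293 cells (Homo sapiens) for cytotoxicity, read by CellTiter-Glo and resazurin assay, with a stated time of 72 h (on this read-out lower numbers stand for an effect already at smaller amounts and higher numbers for an effect only at larger amounts of compound), and for compound 3 the result is only a limit of the assay, > 26000 nM. Two close relatives share the same fate. Compound 1 `COc1cccc(-c2ccc(C(=O)N(Cc3cccc(OCCCCCC(=O)O)c3)C(C)C)cc2)c1` gives a limit too, > 20900 nM. Compound 2 `CC(C)N(Cc1cccc(OCCCCCC(=O)O)c1)C(=O)c1ccc(-c2ccc3[nH]ccc3c2)cc1` likewise gives a limit, > 26000 nM. Because all three results sit at the limit of > 20900 nM in this assay, at which 1 of the 3 values shown sits, or at the limit of > 26000 nM in this assay, at which 2 of the 3 values shown sit, none of the steps among them can be read: a step that the two limits leave unreadable from compound 1 to compound 2, a step that the two limits leave unreadable from compound 1 to compound 3 and a step that the two limits leave unreadable from compound 2 to compound 3 are all of unknown size and direction. So compound 3 stands among equals, none of them showing an effect on the cells within the tested range.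

The new compound 4 `COc1cc(F)cc(-c2ccc(C(=O)N(Cc3cccc(OCCCCCC(=O)O)c3)C(C)C)cc2)c1` differs from compound 3 by one change: 3-fluoro-5-methoxyphenyl in place of 3-hydroxyphenyl on an aromatic carbon. Among the measured compounds shown here, no measured step bears on this change directly, and the three available steps are all hidden by limits. The expected step from compound 3 to compound 4 in this assay is therefore an at least 1.0-fold lower number from compound 3 to compound 4 (0.01 log units; that floor lies within the scatter), nothing beyond the scatter. For compound 4 the expected result in this assay is 25000 nM, within a range from 10000 nM to 60000 nM, most likely reported again only as a limit.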

Compound 4, half-maximal effective concentration: > 26000 nM
Compound 4: only a limit was reported; the forecaster's own chance of this, stated with the estimate: 80%; middle value at least 1.0-fold (0.01 log units) away from the limit.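

In this assay, among the compounds shown here, compound 4 gives only a limit, as do compound 1, compound 2 and compound 3, so no step from any of them to compound 4 can be read: the limit of > 26000 nM in this assay, at which 3 of the 4 values shown sit. The compounds shown leave open at what concentration, if any, each would affect these cells, and whether any of these changes matters.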